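One More Carbon on a Long Chain

This account rests on a few compounds, and the source may have more. Where it says the series, first, only, none or still open, it means among the compounds named here.

In a functional assay (brain) for inhibition, with Rattus norvegicus as the target (a lower number here means a stronger inhibitor, a higher number a weaker inhibitor), compound 1 (`CCCCCCCCCCCCCCCOC1=C(O)OC(C(O)CO)C1=O`) gives 5600 nM and compound 2 (`CCCCCCCCCCCCCCCCCCCCOC1=C(O)OC(C(O)CO)C1=O`) gives 4700 nM as its reading. Within the data shown here, compound 2 has the lowest of only two numbers, yet the pair lies within the usual scatter, so the two compounds stand level. Compound 3 (`CCCCCCCCCCCCCCCCCCCCCOC1=C(O)OC(C(O)CO)C1=O`) differs from compound 2 in one place (methyl in place of hydrogen on a saturated chain carbon, ten or more bonds along the chain from an oxygen on an unsaturated carbon), with methyl in place of hydrogen on a saturated chain carbon. Among the measured compounds shown here, one measured step bears on this change: pentyl in place of hydrogen on the same chain gave a 1.2-fold lower number from compound 1 to compound 2 (0.08 log units; within the scatter) and stayed within the scatter. A single step is thin evidence, but a methyl change is therefore expected to bring no step beyond the scatter in this assay for this pair. The expected step is a 1.0-fold lower number from compound 2 to compound 3 (0.02 log units; within the scatter) and it lies within the scatter. For compound 3 the estimated value is 4500 nM with an expected range (2200 nM to 9000 nM).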

Compound 3, half-maximal inhibitory concentration: 11000 nM
The estimate for compound 3 lay 2.4-fold (0.39 log units) below the measured number; the measured number lies above the stated range.
By their numbers in this assay, from the lowest: compounds 2, 1 and 3 (each within the scatter of the next, the first and the last beyond it).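

In this assay, methyl in place of hydrogen at this place on the chain gives a 2.3-fold higher number from compound 2 to compound 3 (0.37 log units; beyond the scatter) and so, unlike the earlier pentyl step, passes beyond the scatter, if only modestly. A single added carbon can therefore shift the number here, even on a chain that is already long, but the change does not build into a steady trend: the hexyl step gives a 2.0-fold higher number from compound 1 to compound 3 (0.29 log units; within the scatter) and remains within the scatter. Nothing available explains why the methyl step stands out. Whether a longer chain would raise the number further remains open, as only three chain lengths are shown and the one step beyond the scatter is modest. Also open, from the compounds shown here alone, is how a carboxylic acid or an amine at the end of the chain would read in this assay on the same core.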